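The compounds below may be only part of what the source reports. "The series", "measured", "known", "first", "only" and "open" are said of these compounds alone.

Of the compounds shown here, three built on a shared core have been tested in a functional assay on HeLa cells (Homo sapiens) for cytotoxicity, read by MTT assay, with a stated time of 72 h, tested at 30 uM; a higher number here means more inhibition of growth at the concentration tested, a lower number less inhibition of growth. Compound 1 `Cc1ccnc(/C(N)=N/NC(=S)N2CCOCC2)c1` gives 45.2%, compound 2 `Cc1ccnc(/C(N)=N/NC(=S)N2CCSCC2)c1` gives 78.3%, and compound 3 `N/C(=N\NC(=S)N1CCCC1)c1ccccn1` gives 84.5%. Among the compounds with values here, the only pair that differs in one place is the first two, where a number 33.1 percentage points higher from compound 1 to compound 2 (beyond the scatter) follows a swap on the thiocarbonyl carbon. Compound 3 stands highest of the three numbers, yet its gap to compound 2 lies within the scatter, and only its gap to compound 1 lies beyond it, so it cannot be called the most active of the set.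

Compound 4 `Cc1ccnc(/C(N)=N/NC(=S)N2CCCC2)c1` differs from compound 3 by methyl in place of hydrogen on an aromatic carbon. Within the data shown here, no measured pair differs by exactly this change, so there is no step that bears directly on it; the single measured step, from compound 1 to compound 2, alters a different part of the molecule. Compound 4 is therefore expected to sit close to compound 3, with a number 4.5 percentage points lower from compound 3 to compound 4 (within the scatter) as the estimated step, not beyond the scatter. Compound 4 is estimated at 80%, with a range from 60% to 95%.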

Compound 4, percent growth inhibition at one concentration: 86.4%
The estimate for compound 4 lay 6.4 percentage points below the measured number; the range from low to high includes it.
By their numbers in this assay, from the lowest: compound 1; then compounds 2, 3 and 4 (each within the scatter of the next).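

In this assay, the step for methyl in place of hydrogen on this aromatic carbon, opposite the ring nitrogen, is a number 1.9 percentage points higher from compound 3 to compound 4 (within the scatter), so with pyrrolidin-1-yl on the thiocarbonyl carbon this position carries a methyl without a change that can be told from scatter. With the methyl in place on the shared core, pyrrolidin-1-yl in place of thiomorpholin-4-yl gives a number 8.1 percentage points higher from compound 2 to compound 4 (within the scatter), while pyrrolidin-1-yl in place of morpholin-4-yl gives a number 41.2 percentage points higher from compound 1 to compound 4 (beyond the scatter), so among these three methyl compounds only the morpholin-4-yl compound stands apart from compound 4. Nothing available explains why these numbers fall as they do.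

On these data alone, whether an ethyl, a methoxy or a carboxylic acid on the same aromatic carbon would also leave the number unchanged remains open, as does the effect of a methyl on the other ring carbons. It is also unknown whether the methyl would prove as silent alongside morpholin-4-yl or thiomorpholin-4-yl, and a piperidin-1-yl group on the thiocarbonyl carbon would test how far the pyrrolidin-1-yl result extends.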